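This account rests on a few compounds, and the source may have more. Where it says the series, first, only, none or still open, it means among the compounds named here.

Working notes on the series, read in an ADME assay on microsomes from liver (Homo sapiens) for metabolic stability, read by LC-MS, with NADPH named in the record, with a stated time of 60 min, tested at 1 uM, in the absence of a further agent; on this read-out lower numbers stand for a less stable compound and higher numbers for a more stable compound:

compound 1, `COc1cc(-c2c(C)nc3c(N4CC[C@@H](NC(C)=O)C4)cc(C)nn23)cc(OC)c1OC`: > 95%
compound 2, `COc1ccc(-c2c(C)nc3c(N4CC[C@@H](NC(C)=O)C4)cc(Cl)nn23)cc1OC`: > 95%
compound 3, `COc1ccc(-c2c(C)nc3c(N4CC[C@@H](NC(=O)NC(C)C)C4)cc(C)nn23)cc1OC`: > 95%

Each of these three readings is a limit of the assay, not a number. Compound 3 therefore stands at the same limit as the other two, and nothing in the present set separates it from them; the limit of > 95% in this assay, at which 3 of the 3 values shown sit, holds for every value shown. Among the compounds with values here, no step between two measured compounds that differ in a single place is available, and compounds 1 and 2 differ from compound 3 in more than one place, so their values show only that all three sit at the limit.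

The next compound, compound 4, `COc1ccc(-c2c(C)nc3c(N4CC[C@@H](NS(N)(=O)=O)C4)cc(C)nn23)cc1OC`, is to be read in this assay. It differs from compound 3 as follows: sulfamoyl in place of isopropylcarbamoyl on an amine nitrogen.

Within the data shown here, with every measured value at the limit and no single-place step to draw on, the expectation for compound 4 rests on the position of compound 3 alone. The step from compound 3 to compound 4 is expected to be a number at least 2 percentage points lower from compound 3 to compound 4 (that floor lies within the scatter), which is within the scatter of this kind of measurement. For compound 4 the expected value in this assay is 93%, with a range from 80% to 100%, and a limit reading rather than a number is the more likely outcome.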

Compound 4, percent of the compound remaining: > 95%
Compound 4 gave a limit, no number; the forecaster's own chance of this, stated with the estimate: 60%; at least 2 percentage points between middle value and limit.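

In this assay compound 4 gives > 95%, a limit and not a number. Compound 3 also reads as a limit, so no step can be read from compound 3 to compound 4: the limit of > 95% in this assay, at which 4 of the 4 values shown sit.

The compounds shown leave open whether sulfamoyl in place of isopropylcarbamoyl changes the read-out at all, and whether any of the four compounds differ in this assay.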